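This account rests on a few compounds, and the source may have more. Where it says the series, first, only, none or still open, it means among the compounds named here.

Of the compounds shown here, three have been measured in a physicochemical assay for solubility, measured as kinetic solubility; on this read-out lower numbers stand for lower solubility and higher numbers for higher solubility. Compound 1 `Cc1cnc(NC(=O)c2cc(Oc3cnc(C(=O)N(C)C)cn3)c3cc(C)oc3c2)cn1` gives 176000 nM, compound 2 `Cc1cc2c(Oc3cnc(C(=O)N4CC(C)(O)C4)cn3)cc(C(=O)Nc3cnccn3)cc2o1` gives 137000 nM, and compound 3 `Cc1cc2c(Oc3cnc(C(=O)N(C)C)cn3)cc(C(=O)Nc3cnccn3)cc2o1` gives 30000 nM, the lowest of the three numbers. Compound 4 `CCc1cnc(NC(=O)c2cc(Oc3cnc(C(=O)N(C)C)cn3)c3cc(C)oc3c2)cn1` differs from compound 3 in one place, with ethyl in place of hydrogen on an aromatic carbon, so that pyrazin-2-yl becomes 5-ethylpyrazin-2-yl: ethyl in place of hydrogen on an aromatic carbon.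

Two measured steps offer guidance. The more relevant is a 5.9-fold lower number from compound 1 to compound 3 (0.77 log units; beyond the scatter), where hydrogen takes the place of methyl on an aromatic carbon. Read in reverse, that step adds a methyl to compound 3 and gives a higher number, while compound 4 adds an ethyl instead. The other is a 4.6-fold lower number from compound 2 to compound 3 (0.66 log units; beyond the scatter), a change on a carbonyl carbon that compound 4 leaves untouched, so it shows only how far one change has moved this read-out. For the measured compounds named here, no measured compound carries an ethyl, which leaves the size of the step uncertain. The expectation is a modest rise of somewhat smaller size than the methyl step, estimated as a 3.0-fold higher number from compound 3 to compound 4 (0.48 log units; beyond the scatter). For compound 4, the estimated value in this assay is 90000 nM, with an expected range from 25000 nM to 250000 nM.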

Compound 4, solubility: 117000 nM
Compound 4: middle estimate off by 1.3-fold (0.11 log units), on the low side; measured number inside the range.
By their numbers in this assay, from the lowest: compound 3; then compounds 4, 2 and 1 (each within the scatter of the next).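

In this assay, this carbon of the pyrazine ring accepts more than a methyl group: placing ethyl there gives a 3.9-fold higher number from compound 3 to compound 4 (0.59 log units; beyond the scatter) and so shows that a rise at this position is not confined to compound 1. Going from the methyl group to the ethyl group, a change of one carbon further out on the same chain, gives a 1.5-fold lower number from compound 1 to compound 4 (0.18 log units; within the scatter) and stays within the scatter, so the two groups cannot be told apart on this read-out and a longer group at this position has not moved the number any further so far. Nothing measured here explains why either group changes the number.

Still open, from the compounds shown here alone, is whether the trend continues with a longer chain such as propyl, or whether a branched isopropyl group, a cyclopropyl ring, an amine or a carboxylic acid on the same carbon would give a different number. Also open, going by these compounds, is whether adding ethyl would change the number in the same way on compound 2, which carries 3-hydroxy-3-methylazetidin-1-yl on its carbonyl in place of dimethylamino.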